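The source may hold more compounds than are shown below. What is called first, only, known or untested is meant among the compounds shown, and "the series" means these compounds.

Measured compounds:
compound 1 `C=CCn1c(=O)n(C2OC(CO[Si](c3ccccc3)(c3ccccc3)C(C)(C)C)[C@@H](O)[C@H]2O)c2nc(N)nc(O)c21` — 18 uM
compound 2 `Nc1nc(O)c2c(n1)n(C1OC(CO)[C@@H](O)[C@H]1O)c(=O)n2Cc1ccc([N+](=O)[O-])cc1` — 40 uM
compound 3 `C=CCSc1nc2c(O)nc(N)nc2n1C1OC(CO)[C@@H](O)[C@H]1O` — 107 uM

All three share a core that carries a sugar and an amino group, and all were tested in a functional assay (B cells) with Mus musculus as the target; on this read-out lower numbers stand for an effect already at smaller amounts and higher numbers for an effect only at larger amounts of compound. Compound 2 gives 40 uM in this assay, the second highest of the three numbers: compound 1 sits at a lower number, a gap beyond the usual scatter, and compound 3 at a higher number, again beyond the scatter. Compound 2 therefore stands in the middle of the small set, with no neighbour close enough to count as equal.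

Compound 4 `[N-]=[N+]=NCC(O)Cn1c(=O)n(C2OC(CO)[C@@H](O)[C@H]2O)c2nc(N)nc(O)c21` has not yet been measured. It differs from compound 2 in one place: 2-azido-1-hydroxyethyl in place of 4-nitrophenyl on a saturated chain carbon bound to an aromatic nitrogen. A flat ring bearing two acceptors is replaced by a short, open chain that brings one donor and two acceptors, at the same carbon bound to the aromatic nitrogen.

Within the data shown here, no measured pair in the set shows what such a swap does, so the expectation rests on the spread of the three numbers alone. The step from compound 2 to compound 4 is expected to be modest, a 1.4-fold higher number from compound 2 to compound 4 (0.14 log units; within the scatter), with a slight lean toward a higher number. Compound 4 is therefore expected to give about 55 uM in this assay, within a range from 15 uM to 180 uM.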

Compound 4, concentration for half-maximal effect: 39 uM
Compound 4: middle estimate off by 1.4-fold (0.15 log units), on the high side; measured number inside the range.
By their numbers in this assay, from the lowest: compound 1; then compounds 4 and 2 (each within the scatter of the next); then compound 3.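

The swap of 4-nitrophenyl for 2-azido-1-hydroxyethyl on a saturated chain carbon bound to an aromatic nitrogen gives a 1.0-fold lower number from compound 2 to compound 4 (0.01 log units; within the scatter) in this assay, so the two compounds count as equal on this read-out. Among these compounds, this is the first pair in the set that differs in one place, and it shows that, for these two groups, the number stays within the scatter even though a six-membered aromatic ring of carbon only with 9 heavy atoms leaves, and an open chain with no ring, 6 heavy atoms and 1 hydrogen-bond donor enters. No measurement comes with this result that would explain why the two groups give matching numbers.

Still open, from the compounds shown here alone, is whether any group on this carbon would shift the number, since an amine, a carboxylic acid or a longer chain in the same place might not match these two, and the azido group and the hydroxyl within the new chain cannot be told apart. Compound 1 and compound 3 each differ from compound 2 in more than one place, so they cannot settle these questions.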